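Dichloropurine benzyl chlorides: effect of removing one core chloro

This account rests on a few compounds, and the source may have more. Where it says the series, first, only, none or still open, it means among the compounds named here.

Of the compounds shown here, two carry numbers so far. Compound 1 `ClCc1cccc(Cn2cnc3c(Cl)nc(Cl)nc32)c1` and compound 2 `ClCc1ccc(Cn2cnc3c(Cl)nc(Cl)nc32)cc1` share the same core and differ only in the placement of the chloromethyl group on the benzyl ring. In a functional assay on MCF7 cells (Homo sapiens) for cytotoxicity, read by sulforhodamine B assay, with a stated time of 48 h (a lower number here means a stronger inhibitor of growth, a higher number a weaker inhibitor of growth), compound 1 gives 2040 nM, and compound 2 gives 1740 nM; the two values lie within the scatter of each other, so no order between them can be read. Compound 3 `ClCc1cccc(Cn2cnc3c(Cl)ncnc32)c1` is not yet measured. It differs from compound 1 by hydrogen in place of chloro on an aromatic carbon. For the measured compounds named here, no measured pair isolates this change, so its size is unknown. The step from compound 1 to compound 3 in this assay is expected to be modest and, if anything, toward a higher number, estimated as a 1.5-fold higher number from compound 1 to compound 3 (0.17 log units; within the scatter). Compound 3 is accordingly expected to give about 3000 nM, within a range of 1200 nM to 9000 nM.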

Compound 3, concentration for 50% growth inhibition: 7760 nM
Compound 3: middle estimate off by 2.6-fold (0.41 log units), on the low side, and the stated range covers the measured number.
By their numbers in this assay, from the lowest: compounds 2 and 1 (each within the scatter of the next); then compound 3.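

In this assay, replacing the chloro between the two ring nitrogen atoms with hydrogen gives a 3.8-fold higher number from compound 1 to compound 3 (0.58 log units; beyond the scatter), so growth inhibition in this series responds to this position. For the compounds shown here, this is the first difference to lie beyond the scatter, whereas moving the chloromethyl group leaves compound 1 and compound 2 within the scatter of each other. Nothing at hand accounts for the size of this step.

Going by these compounds, whether the loss follows from removing the chloro itself or would also occur with another replacement remains open; an amine, a methoxy group or a methyl group at this position would test this. Also open, on these data alone, are whether the same change on compound 2 gives a step of similar size and what the other chloro on the core, retained in compound 3, contributes.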